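Stability of a pyridone analogue on mouse liver microsomes

This account rests on a few compounds, and the source may have more. Where it says the series, first, only, none or still open, it means among the compounds named here.

Three compounds share one core and differ only in the group fixed to the outer aromatic ring. Compound 1 `CCCCc1[nH]c(=O)c(S(=O)(=O)c2ccc(-c3ccc(F)cc3)cc2)c(O)c1-c1c(OC)cccc1OC` carries a fluorophenyl group there; in an ADME assay on microsomes from liver (Mus musculus) for metabolic stability, using NADPH, with a stated time of 10 min (on this read-out higher numbers stand for a more stable compound and lower numbers for a less stable compound), compound 1 gives "not determined" (no result reported), so no result for it was reported. Compound 2 `CCCCc1[nH]c(=O)c(S(=O)(=O)c2ccc(-c3cccnc3OC)cc2)c(O)c1-c1c(OC)cccc1OC` carries a 2-methoxypyridin-3-yl group, and in this assay compound 2 gives 24%. Within the data shown here, that is the only number in this assay, so compound 2 stands alone and cannot be ranked against anything. Compound 3 `CCCCc1[nH]c(=O)c(S(=O)(=O)c2ccc(-n3ccccc3=O)cc2)c(O)c1-c1c(OC)cccc1OC` is not yet measured. It differs from compound 2 in one place: a group of 7 heavy atoms (5 carbon, 1 nitrogen, 1 oxygen; one six-membered aromatic ring with 1 hetero atom) in place of a group of 8 heavy atoms (6 carbon, 1 nitrogen, 1 oxygen; one six-membered aromatic ring with 1 hetero atom), on an aromatic carbon, para to a large group. Among the measured compounds shown here, no pair of measured compounds shows what such a swap does here, so the expected step of a number 8 percentage points higher from compound 2 to compound 3 (within the scatter) is a modest rise that may not exceed the usual scatter. Compound 3 is estimated at 32%, with a range from 14% to 58% in this assay.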

Compound 3, percent of the compound remaining: 75%
Beside the measured number, compound 3's estimate is 43 percentage points below it; the measured number lies above the stated range.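

In this assay the exchange of the 2-methoxypyridin-3-yl group for the entering group gives a number 51 percentage points higher from compound 2 to compound 3 (beyond the scatter) and is a large step, so the group on this aromatic carbon, para to a large group, can strongly change the percent of compound remaining. A single number could not show this, since one compound alone gives no sense of how much this place matters. The two groups have the same counts of hydrogen-bond donors and acceptors and neither has a net charge, so those counts do not separate them, and nothing shown says which difference in the groups accounts for the step.

Compound 1, with its fluorophenyl group, stands at "not determined" (no result reported) in this read-out, so it offers no third point for comparison at this place. As far as these compounds go, whether other groups there, such as a morpholine ring or a carboxylic acid, would behave like the group in compound 3 remains open, as does the effect of changing another part of the shared core, such as replacing the butyl chain with a longer chain.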